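The source may hold more compounds than are shown below. What is called first, only, known or untested is meant among the compounds shown, and "the series" means these compounds.

In an in vitro ADME assay on microsomes from liver (Homo sapiens) for metabolic stability, in the presence of a further agent that is not named here (a higher number here means faster removal of the compound, a lower number slower removal), compound 1 (`CC(C)(CO)CNC(=O)c1cc2cc(C#N)ccc2n1Cc1cc(Cl)cc(Cl)c1`) gives 22 mL.min-1.g-1 and compound 2 (`Cc1ccc(F)cc1Cn1c(C(=O)NCC2(CO)CCC2)cc2cc(C#N)ccc21`) gives 49 mL.min-1.g-1. Compound 3 (`CC(C)(O)CCNC(=O)c1cc2cc(C#N)ccc2n1Cc1cccc(OC(F)(F)F)c1`) returns only a limit, < 6 mL.min-1.g-1, and not a number. That places it at the low end of the three readings. Compound 4 (`CC(O)C1(CNC(=O)c2cc3cc(C#N)ccc3n2Cc2cccc(OC(F)(F)F)c2)CCCC1`) differs from it in one place: a group of 8 heavy atoms (7 carbon, 1 oxygen; one five-membered non-aromatic ring of carbon only) in place of a group of 5 heavy atoms (4 carbon, 1 oxygen; no ring), on a saturated chain carbon bound to an amide-type nitrogen. Within the data shown here, no measured pair isolates such a change, so its effect can only be estimated. The expectation of faster removal leans on compound 2, whose ring-bearing side chain goes with 49 mL.min-1.g-1. The expected rise, beyond the usual scatter, is estimated as an at least 3.0-fold higher number from compound 3 to compound 4 (0.47 log units; beyond the scatter). Compound 4 is expected to read about 18 mL.min-1.g-1, with an estimated range of 7 mL.min-1.g-1 to 45 mL.min-1.g-1.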

Compound 4, intrinsic clearance in microsomes: 9 mL.min-1.g-1
Estimate against measurement, compound 4: 2.0-fold (0.30 log units) above, and the stated range covers the measured number.
By their numbers in this assay, from the lowest: compound 4; then compound 1; then compound 2. At a limit, below all of these: compound 3.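

The change from 2-hydroxy-2-methylpropyl to the group carrying a five-membered carbon ring gives, in this assay, an at least 1.5-fold higher number from compound 3 to compound 4 (0.17 log units; that floor lies within the scatter). With the ring-bearing group in this place, compound 4 reads 9 mL.min-1.g-1, so this pair alone does not establish a rise beyond the scatter. The true size of the step cannot be read, because only a floor can be drawn from a limit: the limit of < 6 mL.min-1.g-1 in this assay, at which 1 of the 4 values shown sits.

The compounds shown leave open how an amine or a carboxylic acid would read on this saturated chain carbon. They also leave open how a longer open chain would read there.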